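A few compounds are considered here, and "the series" means these few. Any claim that something is new, unique, unknown or untested is made for them only; others in the source may bear on it.

Measured compounds in an assay on microsomes from intestine for inhibition of acyl-CoA:cholesterol acyltransferase (Oryctolagus cuniculus); on this read-out higher numbers stand for weaker inhibition and lower numbers for stronger inhibition:
compound 1 `CC(C)c1cccc(C(C)C)c1NC(=O)NC(=O)OC(c1ccccc1)c1ccccc1` gives 7800 nM
compound 2 `CC(C)c1cccc(C(C)C)c1OC(=O)NC(=O)OCc1ccccc1` gives 77 nM
compound 3 `CCCCCCCCCCOC(=O)NC(=O)Oc1c(C(C)C)cccc1C(C)C` gives 74 nM

Compound 3 sits with compound 2 at the low end of the set, the two within the scatter of each other, while compound 1 lies well apart. Compound 4 `CCCCCCCCCCCCCCOC(=O)NC(=O)Oc1c(C(C)C)cccc1C(C)C` differs from compound 3 by butyl in place of hydrogen on a saturated chain carbon, ten or more bonds along the chain from an oxygen next to a carbonyl group. Within the data shown here, no measured step extends this chain in the same way. Among the measured compounds shown here, the one measured step that alters the chain, a 1.0-fold lower number from compound 2 to compound 3 (0.02 log units; within the scatter), lay within the scatter. Nothing in this assay therefore supports a shift beyond the scatter in either direction, and the expected step of a 1.1-fold lower number from compound 3 to compound 4 (0.02 log units; within the scatter) is set near zero. Compound 4 is thus estimated at 70 nM, with a range from 25 nM to 200 nM.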

Compound 4, half-maximal inhibitory concentration: 10 nM
The estimate for compound 4 lay 7.0-fold (0.85 log units) above the measured number, outside the stated range (below it).
By their numbers in this assay, from the lowest: compound 4; then compounds 3 and 2 (each within the scatter of the next); then compound 1.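

In this assay, butyl in place of hydrogen on a saturated chain carbon, ten or more bonds along the chain from an oxygen next to a carbonyl group, gives a 7.4-fold lower number from compound 3 to compound 4 (0.87 log units; beyond the scatter), a step beyond the scatter. The number here therefore responds to extending the chain, which the earlier change, a 1.0-fold lower number from compound 2 to compound 3 (0.02 log units; within the scatter), within the scatter, did not show. Nothing measured here bears on the cause of this step.

From the compounds shown here alone, whether a longer chain lowers the number further remains open, as does the effect of an amine or a carboxylic acid on this chain.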